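Hydroxy on the benzyl ring of compound 3

The compounds below may be only part of what the source reports. "The series", "measured", "known", "first", "only" and "open" are said of these compounds alone.

In an ADME assay on MT4 cells (Homo sapiens) for cytotoxicity, read by MTT assay, with a stated time of 3 days (on this read-out higher numbers stand for lower toxicity in this test and lower numbers for higher toxicity in this test), the compounds give these values, a sign marking a limit of the assay:
Compound 1 `O=C(COC(=O)c1ccc([N+](=O)[O-])o1)NCC1CCCO1` gives > 100000 nM
Compound 2 `CC(C)(C)N(Cc1ccccc1C(F)(F)F)C(=O)COC(=O)c1ccc([N+](=O)[O-])o1` gives 95000 nM
Compound 3 `O=C(OCC(=O)N(Cc1ccccc1)CC1CCCO1)c1ccc([N+](=O)[O-])o1` gives > 100000 nM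

Compound 3 stands at > 100000 nM, which is a limit and not a number. That is the limit of > 100000 nM in this assay, at which 2 of the 3 values shown sit, here. Compound 4 `O=C(OCC(=O)N(Cc1ccc(O)cc1)CC1CCCO1)c1ccc([N+](=O)[O-])o1` carries hydroxy in place of hydrogen on an aromatic carbon on the benzyl group, so benzyl becomes 4-hydroxybenzyl. Among the measured compounds shown here, the one measured step that bears on this group is a step that the two limits leave unreadable from compound 1 to compound 3 and it offers no size to carry over. No direction can be read from it, so in this assay no change beyond the scatter is expected. The expected step is an at least 1.0-fold lower number from compound 3 to compound 4 (0.02 log units; that floor lies within the scatter) as an estimate. Compound 4 is expected at 95000 nM (estimated range 40000 nM to 150000 nM).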

Compound 4, half-maximal cytotoxic concentration: > 100000 nM
Compound 4: only a limit was reported; the forecaster's own chance of this, stated with the estimate: 60%; at least 1.0-fold (0.02 log units) between middle value and limit.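

Among the compounds shown here, compound 4 gives > 100000 nM, which is a limit of the assay, so no step from compound 3 or compound 1 to compound 4 can be read. The compounds shown leave open whether hydroxy on the benzyl ring changes the value in this assay at all.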